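Carbamoyl for Hydroxymethyl: Expected Cytotoxicity of Compound 4

The source may report more compounds than this note shows. Statements on the series, on what has been measured and on what is new or still open speak of the compounds shown alone.

Measured so far in an ADME assay on TZM cells (Homo sapiens) for cytotoxicity, read by XTT assay, with a stated time of 4 days; on this read-out higher numbers stand for lower toxicity in this test and lower numbers for higher toxicity in this test:
Compound 1 `Cc1cc(CO)cc(C)c1Oc1cc(Nc2ccc(C#N)cc2)c(N)cc1CO` gives 15900 nM.
Compound 2 `Cc1cc(N)cc(C)c1Oc1cc(Nc2ccc(C#N)cc2)c(N)cc1C(F)(F)F` gives 15800 nM.
Compound 3 `Cc1cc(/C=C/C#N)cc(C)c1Oc1cc(Nc2ccc(C#N)cc2)c(N)cc1CO` gives 16300 nM.

Compound 3 carries the highest of the three numbers, but its distance to compound 1 and to compound 2 lies within the usual scatter, so the three compounds cannot be told apart on this read-out, and none may be called less toxic than the others.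

Compound 4 `Cc1cc(/C=C/C#N)cc(C)c1Oc1cc(Nc2ccc(C#N)cc2)c(N)cc1C(N)=O` differs from compound 3 in one place: carbamoyl in place of hydroxymethyl on an aromatic carbon. Going by the values given here, the only step recorded between measured compounds is a 1.0-fold higher number from compound 1 to compound 3 (0.01 log units; within the scatter), which changed a different part of the molecule and left the number where it was. Among the compounds with values here, no measured pair replaces hydroxymethyl with carbamoyl, so there is no direct precedent for this change. Compound 1 and compound 2, which carry different groups at this place among other differences, show values within the scatter of each other. On this basis no step beyond the scatter is expected, and the estimated change is a 1.0-fold lower number from compound 3 to compound 4 (0.01 log units; within the scatter). Compound 4 is therefore expected to give about 16000 nM, within a range of 8000 nM to 32000 nM.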

Compound 4, half-maximal cytotoxic concentration: > 23600 nM
Compound 4: only a limit was reported (the forecaster's own chance of this, stated with the estimate: 10%); middle value at least 1.4-fold (0.16 log units) from the limit.
By their numbers in this assay, from the lowest: compounds 2, 1 and 3 (each within the scatter of the next). At a limit, above all of these: compound 4.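

In this assay, going by these compounds alone, compound 4 gives the first view of a change at this aromatic carbon on its own, para to the (4-cyanophenyl)amino group, with the rest of the molecule held constant: carbamoyl in place of hydroxymethyl gives an at least 1.4-fold higher number from compound 3 to compound 4 (0.16 log units; that floor lies within the scatter). Compound 4 gives > 23600 nM, which is a limit and not a number. The change shows no sign of a lower number at this place, which would have meant higher toxicity in this test, but the floor of the step lies within the scatter, so compound 4 cannot yet be called less toxic than compound 3, and the result rests on a single reading at the limit: the limit of > 23600 nM in this assay, at which 1 of the 4 values shown sits.

From the compounds shown here alone, how far the true number of compound 4 lies past its limit stays open, as does whether the same swap would read alike in compound 1, which carries hydroxymethyl where compound 3 carries 2-cyanoethenyl. Also open, going by these compounds, is how a carboxylic acid or an aminomethyl group at this place would read in this assay.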